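The source may report more compounds than this note shows. Statements on the series, on what has been measured and on what is new or still open speak of the compounds shown alone.

Compound 1 `c1cncc(-c2nc3ccccn3c2NC2CCCC2)c1` has been tested for harm to cells in an ADME assay on THP-1 cells (Homo sapiens) for cytotoxicity; on this read-out lower numbers stand for higher toxicity in this test and higher numbers for lower toxicity in this test. In this test compound 1 gives > 50000 nM, which is a limit of the assay and not a number. Compound 2 `Cc1ccn2c(NC3CCCC3)c(-c3ccc(N(C)C)cc3)nc2c1` gives > 50000 nM, which is again a limit. The picture so far is therefore a single one: the limit of > 50000 nM in this assay, at which 2 of the 2 values shown sit. Compound 1 thus stands at that limit, with no exact number to place it by.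

Compound 3 `Cn1ccnc1-c1nc2ccccn2c1NC1CCCC1` keeps the core of compound 1 and its cyclopentylamino group, and alters one substituent: 1-methyl-1H-imidazol-2-yl in place of pyridin-3-yl on an aromatic carbon. In words, 1-methyl-1H-imidazol-2-yl stands in place of pyridin-3-yl on an aromatic carbon. Within the data shown here, no measured pair shows what this swap does in this assay, so no step beyond the usual scatter is expected, in either direction. That expectation leans on compound 1 and its limit of > 50000 nM. The expected a number no higher from compound 1 to compound 3 (the limit leaves the size open) is accordingly small. Compound 3 is estimated at 50000 nM, with an expected range of 25000 nM to 100000 nM.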

Compound 3, half-maximal cytotoxic concentration: > 50000 nM
Compound 3 gave a limit, no number; the forecaster's own chance of this, stated with the estimate: 85%; the middle value sits exactly at the limit.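

No step can be read from compound 1 to compound 3 because both stand at a limit and not at a number: the limit of > 50000 nM in this assay, at which 3 of the 3 values shown sit.

The compounds shown leave open how far each lies beyond that limit, and whether 1-methyl-1H-imidazol-2-yl in place of pyridin-3-yl on an aromatic carbon changes the read-out at all.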